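The source may hold more compounds than are shown below. What is called first, only, known or untested is meant among the compounds shown, and "the series" means these compounds.

Three compounds have so far been measured in an assay on U2OS cells for inhibition of secreted frizzled-related protein 1 (Homo sapiens), read by a luciferase reporter, with a stated time of 18 h; a lower number here means that less compound is needed, a higher number that more compound is needed for the effect:
compound 1 `O=C(c1cccc(Cl)c1)N1CCC(NS(=O)(=O)c2cc(S(=O)(=O)c3ccccc3)ccc2C(F)(F)F)CC1`, 870 nM;
compound 2 `O=C(O)c1ccc(N2CCC(NS(=O)(=O)c3cc(S(=O)(=O)c4ccccc4)ccc3C(F)(F)F)CC2)cc1`, 230 nM;
compound 3 `CC(C)(C)OC(=O)N1CC[C@@H](C(=O)N2CCC(NS(=O)(=O)c3cc(S(=O)(=O)c4ccccc4)ccc3C(F)(F)F)CC2)C1`, 80 nM.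

Compound 3 gives the lowest number of the three. Its nearest neighbour is compound 2 and its furthest is compound 1, and both of those gaps lie beyond the usual scatter of this assay. Compound 4 `O=C([C@H]1CCNC1)N1CCC(NS(=O)(=O)c2cc(S(=O)(=O)c3ccccc3)ccc2C(F)(F)F)CC1` has not yet been measured. It differs from compound 3 in one place: pyrrolidin-3-yl in place of 1-(tert-butoxycarbonyl)pyrrolidin-3-yl on a carbonyl carbon. For the measured compounds named here, two measured steps touch this part of the shared core. In the step of an 11-fold lower number from compound 1 to compound 3 (1.04 log units; beyond the scatter) the group attached to the carbonyl carbon was exchanged, and in the step of a 3.8-fold lower number from compound 1 to compound 2 (0.58 log units; beyond the scatter) the carbonyl group itself was replaced. Going by the values given here, neither step removes a tert-butoxycarbonyl from a pyrrolidine nitrogen, so no measured step matches the present change directly. The expectation for compound 4 in this assay is therefore a small step, a 1.5-fold higher number from compound 3 to compound 4 (0.18 log units; within the scatter), not clearly beyond the scatter. The estimate for compound 4 is 120 nM, with a range from 40 nM to 400 nM.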

Compound 4, half-maximal effective concentration: 700 nM
For compound 4 the middle estimate is 5.8-fold (0.77 log units) below the measured one; measured number outside the range, above it.
By their numbers in this assay, from the lowest: compound 3; then compound 2; then compounds 4 and 1 (each within the scatter of the next).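

In this assay, taking the tert-butoxycarbonyl group off the ring nitrogen gives an 8.8-fold higher number from compound 3 to compound 4 (0.94 log units; beyond the scatter), so the low number of compound 3 depends on that group and not on the pyrrolidine ring alone. On this carbonyl carbon, the bare pyrrolidin-3-yl group cannot be told apart from 3-chlorophenyl, with a 1.2-fold lower number from compound 1 to compound 4 (0.09 log units; within the scatter) lying within the scatter, while a 3.0-fold higher number from compound 2 to compound 4 (0.48 log units; beyond the scatter) lies beyond it. No measured evidence here bears on the reason for these differences.

On these data alone, it remains open whether the whole tert-butoxycarbonyl group is needed, or whether a smaller acetyl or methyl group on the same ring nitrogen would restore the low number. As far as these compounds go, it is also open how the opposite configuration at the defined stereocentre would compare.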